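Dimethylamino in Place of Nitro: a Cytotoxicity Estimate

The source may report more compounds than this note shows. Statements on the series, on what has been measured and on what is new or still open speak of the compounds shown alone.

Compound 1 `CC(/C=N/Nc1ccc([N+](=O)[O-])cc1)=N\NC(=O)c1ccc([N+](=O)[O-])cc1`: > 100000 nM in an ADME assay on J774 cells (Mus musculus, strain BALB/c) for cytotoxicity, read by resazurin assay, with a stated time of 72 h (on this read-out higher numbers stand for lower toxicity in this test and lower numbers for higher toxicity in this test), a limit of the assay.
Compound 2 `COc1cc(C(=O)N/N=C(C)/C=N/Nc2ccc([N+](=O)[O-])cc2)ccc1O`: > 100000 nM in this assay, also a limit.
Compound 3 `CC(/C=N/Nc1ccc([N+](=O)[O-])cc1)=N\NC(=O)c1ccc(N)cc1`: 75000 nM in this assay.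

Compound 1 stands at the limit of > 100000 nM in this assay, at which 2 of the 3 values shown sit, so only a limit is known for it, not a number. Compound 4 `CC(/C=N/Nc1ccc([N+](=O)[O-])cc1)=N\NC(=O)c1ccc(N(C)C)cc1` differs from compound 1 by dimethylamino in place of nitro on an aromatic carbon. The nearest measured step is an at least 1.3-fold lower number from compound 1 to compound 3 (0.12 log units; that floor lies within the scatter), where the same nitro gave way to amino. Compound 2 offers no guidance, since a step that the two limits leave unreadable from compound 1 to compound 2. Because an at least 1.3-fold lower number from compound 1 to compound 3 (0.12 log units; that floor lies within the scatter) has a floor inside the scatter, the step of an at least 1.2-fold lower number from compound 1 to compound 4 (0.09 log units; that floor lies within the scatter) is expected to be small, quite possibly ending again at the limit. Compound 4 is therefore estimated at 80000 nM, with a range from 30000 nM to 200000 nM.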

Compound 4, half-maximal cytotoxic concentration: > 100000 nM
Compound 4 ended at the assay's limit (the forecaster's own chance of this, stated with the estimate: 40%); middle value at least 1.2-fold (0.09 log units) away from the limit.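

Dimethylamino in place of amino at this position gives an at least 1.3-fold higher number from compound 3 to compound 4 (0.12 log units; that floor lies within the scatter), so this floor alone does not separate the two groups. The steps from compound 1 and from compound 2 to compound 4 cannot be read, since both ends of each are limits. In this assay, compound 4 also gives only a limit, so most of this small set now has no number: the limit of > 100000 nM in this assay, at which 3 of the 4 values shown sit.

As far as these compounds go, whether methylamino or a carboxylic acid at the same position would give a number or another limit remains open. From the compounds shown here alone, the true values of compounds at the limit also remain unknown.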